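This account rests on a few compounds, and the source may have more. Where it says the series, first, only, none or still open, it means among the compounds named here.

In a functional assay on HepG2 cells (Homo sapiens) for antiproliferative activity, read by MTT assay, with a stated time of 48 h (a lower number here means a stronger inhibitor, a higher number a weaker inhibitor), compound 1 `O=C(/C=C/c1ccccc1)Nc1cc2c(Nc3ccc(F)c(Cl)c3)ncnc2s1` gives 22800 nM and compound 2 `N#Cc1cccc(Nc2ncnc3cc(NC(=O)/C=C/c4ccccc4)sc23)c1` gives 15900 nM and these two values lie within the scatter of each other. The change from compound 1 to compound 3 `C#Cc1cccc(Nc2ncnc3sc(NC(=O)/C=C/c4ccccc4)cc23)c1` is 3-ethynylphenyl in place of 3-chloro-4-fluorophenyl on a nitrogen on an aromatic ring and puts 3-ethynylphenyl in place of 3-chloro-4-fluorophenyl on a nitrogen on an aromatic ring. Among the measured compounds shown here, no measured pair differs in one place only, so the data offer no direct guide to this change. The expected step in this assay is a 1.3-fold lower number from compound 1 to compound 3 (0.10 log units; within the scatter) and so stays within the scatter, slightly toward a lower number. For compound 3 the estimate is 18000 nM with an expected range from 7000 nM to 45000 nM at this stage.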

Compound 3, half-maximal inhibitory concentration: 58100 nM
Compound 3: the middle estimate sits 3.2-fold (0.51 log units) below what was measured; measured number above the stated range.
By their numbers in this assay, from the lowest: compounds 2 and 1 (each within the scatter of the next); then compound 3.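

Among the compounds shown here, on a nitrogen on an aromatic ring, 3-ethynylphenyl in place of 3-chloro-4-fluorophenyl gives the first readable single-place step in this assay with a 2.5-fold higher number from compound 1 to compound 3 (0.41 log units; beyond the scatter) and thus shows that the result at this position depends on the aryl group it carries. The compounds at hand give no measurement that accounts for this step.
From the compounds shown here alone, it remains open whether the step follows from gaining the ethynyl group or losing the chlorine and fluorine, which a plain phenyl group would help to separate. Going by these compounds, how a morpholine in place of the aryl amine would read also remains open.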